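A Shorter Ether Tail on the Ring Amine

The source may hold more compounds than are shown below. What is called first, only, known or untested is meant among the compounds shown, and "the series" means these compounds.

Three compounds share one core and differ only in the group on an amine nitrogen in a ring. In an assay on HEK293 cells for displacement of a labelled ligand from growth hormone secretagogue receptor type 1 (Homo sapiens), with a stated time of 60 min (on this read-out lower numbers stand for stronger inhibition and higher numbers for weaker inhibition), compound 1 `COc1cccc(-n2cc3nc(-c4cccnc4C)n(C[C@H]4CCCN(CC5CCOC5)C4)c(=O)c3n2)c1` gives 60 nM, compound 2 `COc1cccc(-n2cc3nc(-c4cccnc4C)n(C[C@H]4CCCN(Cc5ccco5)C4)c(=O)c3n2)c1` gives 2.7 nM, and compound 3 `CCO[C@@H](C)CN1CCC[C@H](Cn2c(-c3cccnc3C)nc3cn(-c4cccc(OC)c4)nc3c2=O)C1` gives 5 nM. Compound 3 sits close to compound 2, a 1.9-fold higher number from compound 2 to compound 3 (0.27 log units; within the scatter), and well apart from compound 1, a 12-fold lower number from compound 1 to compound 3 (1.08 log units; beyond the scatter). Compound 4 `COC[C@H](C)N1CCC[C@H](Cn2c(-c3cccnc3C)nc3cn(-c4cccc(OC)c4)nc3c2=O)C1` is not yet measured; it differs from compound 3 by 1-(methoxymethyl)ethyl in place of 2-ethoxypropyl on an amine nitrogen in a ring. Going by the values given here, no measured step exchanges one open ether chain for another, so guidance is indirect: a 12-fold lower number from compound 1 to compound 3 (1.08 log units; beyond the scatter) involves a ring ether, and a 1.9-fold higher number from compound 2 to compound 3 (0.27 log units; within the scatter) is small. A modest step is expected, a 1.6-fold higher number from compound 3 to compound 4 (0.20 log units; within the scatter). Compound 4 is therefore estimated at 8 nM, with a range from 3 nM to 25 nM.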

Compound 4, half-maximal inhibitory concentration: 1.7 nM
Estimate against measurement, compound 4: 4.7-fold (0.67 log units) above; the whole stated range lies above it.
By their numbers in this assay, from the lowest: compounds 4, 2 and 3 (each within the scatter of the next, the first and the last beyond it); then compound 1.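

Replacing 2-ethoxypropyl with 1-(methoxymethyl)ethyl on this amine nitrogen gives a 2.9-fold lower number from compound 3 to compound 4 (0.47 log units; beyond the scatter) in this assay, so a change between two open ether chains can register here, even though both hold one hydrogen-bond acceptor. Replacing (furan-2-yl)methyl gives a 1.6-fold lower number from compound 2 to compound 4 (0.20 log units; within the scatter), so the open chain matches that ring-bearing group. Replacing (oxolan-3-yl)methyl gives a 35-fold lower number from compound 1 to compound 4 (1.55 log units; beyond the scatter), the widest gap among these compounds. Whether a longer ether chain or a chain ending in an amine would fit as well remains open, and no measured evidence accounts for these steps.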